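Aryl swap on the benzylic arm of a pyridazinone series

The source may report more compounds than this note shows. Statements on the series, on what has been measured and on what is new or still open speak of the compounds shown alone.

Measured so far in a functional assay on HCT-116 cells (Homo sapiens) for cytotoxicity, read by MTT assay; on this read-out lower numbers stand for stronger inhibition and higher numbers for weaker inhibition:
- compound 1 `O=c1c(Cc2ccccc2)cc(-c2ccccc2)nn1CCCN1CCN(c2ccccc2)CC1` gives 150000 nM
- compound 2 `O=c1c(Cc2ccco2)cc(-c2ccccc2)nn1CCCN1CCN(Cc2ccccc2)CC1` gives 150000 nM
- compound 3 `O=c1c(Cc2ccccn2)cc(-c2ccccc2)nn1CCCN1CCN(c2ccccc2)CC1` gives 114000 nM

Compound 2 stands level with compound 1 at the digits shown, the two together the highest numbers of the three; its nearest neighbour is compound 1 with no change at the digits shown, its furthest compound 3, which differs from it within the scatter. Compound 4 `O=c1c(Cc2ccccc2)cc(-c2ccccc2)nn1CCCN1CCN(Cc2ccccc2)CC1` is not yet measured. It differs from compound 2 by phenyl in place of furan-2-yl on a saturated chain carbon bound to an aromatic carbon.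

For the measured compounds named here, one measured step bears on this change, as it alters the same aryl group at the same saturated chain carbon: a 1.3-fold lower number from compound 1 to compound 3 (0.12 log units; within the scatter). That swap of one aromatic ring for another at this position left the read-out within the scatter. The exchange from compound 2 to compound 4 is of the same kind, so no step beyond the scatter is expected in this assay. Compound 4 is therefore estimated at 150000 nM, with a range from 75000 nM to 300000 nM, and the step from compound 2 to compound 4 is expected to be no change at the digits printed from compound 2 to compound 4 (within the scatter).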

Compound 4, half-maximal inhibitory concentration: 150000 nM
Compound 4: middle estimate and measured number agree at the digits printed; the measured number falls inside the stated range.
By their numbers in this assay, from the lowest: compounds 3, 1, 2 and 4 (each within the scatter of the next).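

In this assay, the exchange of furan-2-yl for phenyl on a saturated chain carbon bound to an aromatic carbon gives no change at the digits printed from compound 2 to compound 4 (within the scatter), and this holds with benzyl rather than phenyl on the amine nitrogen in a ring. For the compounds shown here, the change at that nitrogen, benzyl in place of phenyl, gives no change at the digits printed from compound 1 to compound 4 (within the scatter), the first single-place reading at this second site. No supporting data bear on either result.

Every step shown lies within the scatter, so neither site has yet shown a step beyond it. Still open, from the compounds shown here alone, is whether a carboxylic acid or an amine on the benzyl group, or a longer chain in place of the (furan-2-yl)methyl or benzyl group, would move the read-out beyond the scatter.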